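This account rests on a few compounds, and the source may have more. Where it says the series, first, only, none or still open, it means among the compounds named here.

Working notes on the series in a functional assay on M21 cells (Homo sapiens) for cytotoxicity, read by sulforhodamine B assay, with a stated time of 48 h; a higher number here means a weaker inhibitor, a lower number a stronger inhibitor. Compound 1 `CCNC(=O)Nc1ccc(S(=O)(=O)Oc2ccccc2CC)cc1` gives 2500 nM in this assay. Compound 2 `CCCc1ccccc1OS(=O)(=O)c1ccc(NC(=O)NCC)cc1` carries methyl in place of hydrogen on a saturated chain carbon, two bonds along the chain from an aromatic carbon and gives 800 nM in this assay; the step of a 3.1-fold lower number from compound 1 to compound 2 (0.49 log units; beyond the scatter) is a modest gain on the first core.

Compound 3 `CCNC(=O)Nc1cccc(S(=O)(=O)Nc2ccccc2CC)c1` sits on a second core. The difference between the two cores is not broken down here. In this assay compound 3 gives only a limit, > 100000 nM, not a number.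

Compound 4 `CCCc1ccccc1NS(=O)(=O)c1cccc(NC(=O)NCC)c1`, not yet measured, differs from compound 3 by methyl in place of hydrogen on a saturated chain carbon, two bonds along the chain from an aromatic carbon, the same change as that made from compound 1 to compound 2, in the same place. On the first core that change gave the step of a 3.1-fold lower number from compound 1 to compound 2 (0.49 log units; beyond the scatter). Whether it gives a comparable step on the second core is not known, and compound 3 rests at the limit of > 100000 nM in this assay, at which 1 of the 3 values shown sits, so a step of similar size need not bring compound 4 into the measurable range. The expected step is an at least 1.4-fold lower number from compound 3 to compound 4 (0.15 log units; that floor lies within the scatter), resting on that earlier step. Compound 4 is expected to give about 70000 nM in this assay, within 25000 nM to 200000 nM.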

Compound 4, half-maximal inhibitory concentration: 60000 nM
Compound 4: the middle estimate sits 1.2-fold (0.07 log units) above what was measured; the measured number falls inside the stated range.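

In this assay, methyl in place of hydrogen on a saturated chain carbon, two bonds along the chain from an aromatic carbon, gives an at least 1.6-fold lower number from compound 3 to compound 4 (0.22 log units; that floor lies within the scatter), so the second core shows a step in the same direction as the first, though its floor does not clear the scatter. Set side by side, the two steps do not establish that the change carries over with the same size, nor that its size depends on the core: the same change on two cores in this assay, a 3.1-fold lower number (0.49 log units; beyond the scatter) from compound 1 to compound 2 and an at least 1.6-fold lower number (0.22 log units; that floor lies within the scatter) from compound 3 to compound 4; the limit leaves it open whether they differ. Compound 3 has a limit and not a number, so the full size of the step on the second core stays unread, and one pair on each core gives no rule for the series: the limit of > 100000 nM in this assay, at which 1 of the 4 values shown sits.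

The compounds shown leave open whether a longer chain, such as butyl, would continue the step on either core, or whether a chain ending in an amine or a carboxylic acid would follow it. They also leave open which part of the difference between the two cores accounts for the gap between them.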